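Bromo for methyl on the benzyl ether series

The source may hold more compounds than are shown below. What is called first, only, known or untested is meant among the compounds shown, and "the series" means these compounds.

Compound 1 `Cc1ccc(COc2nc3ccccc3s2)cc1` is one of three compounds examined in a functional assay on the whole organism with Mus musculus as the target, in the writhing test, at a dose of 100 mg/kg by the intraperitoneal route; on this read-out higher numbers stand for more inhibition at the one dose given (going by the name of the read-out) and lower numbers for less inhibition. Compound 1 gives "not active" (no number reported) there, so no number is attached to it. Compound 3 `Clc1ccccc1COc1nc2ccccc2s1`, a near relative with the same shared core and ether link, likewise gives "not active" (no number reported). Only compound 2 `Clc1ccc(OCCOc2nc3ccccc3s2)c(Cl)c1`, which differs from both in its longer linker and in its aryl substitution, returns a number: compound 2 gives 68.6% in this assay. Going by the values given here, no pairwise step is available for any two measured compounds, so the two entries reported as not active can only be set beside the single numbered one without a stated size.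

Compound 4 `Brc1ccc(COc2nc3ccccc3s2)cc1` is not yet measured. Its change from compound 1 is bromo in place of methyl on an aromatic carbon. Given that compound 1 and compound 3, both short benzyl ethers, return no number in this assay, the step from compound 1 to compound 4 is expected to be none beyond the scatter, with a real chance that compound 4 is again reported without a number. Compound 4 is estimated at 15% in this assay, within 0% to 40%.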

Compound 4, a percentage reported as inhibition, in the whole organism at one dose (the size of the read-out at that dose, not a potency): 51.9%
Compound 4: the middle estimate sits 36.9 percentage points below what was measured; the whole stated range lies below it.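

No step can be read from compound 1 to compound 4 in this assay: compound 1 carries no number. The compounds shown leave open how large the difference between methyl and bromo at this place is. No measured evidence bears on this result.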